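This account rests on a few compounds, and the source may have more. Where it says the series, first, only, none or still open, it means among the compounds named here.

In a functional assay on HCT-116 cells (Homo sapiens) for antiproliferative activity, read by MTT assay, with a stated time of 72 h (a higher number here means a weaker inhibitor, a lower number a stronger inhibitor), compound 1 (`C=CS(=O)(=O)Nc1ccc(Cl)c(S(=O)(=O)N(C)C)c1`) gives 9900 nM, and compound 2 (`C=CC(=O)Nc1nc(-c2ccc(C(F)(F)F)cc2)cs1`) gives 4000 nM. Compound 3 (`C=CC(=O)N(Cc1ccccc1)c1nc(-c2ccccc2)cs1`) reads > 30000 nM in this assay, which is a limit and not a number. That reading is the limit of > 30000 nM in this assay, at which 1 of the 3 values shown sits.

Compound 4 (`C=CC(=O)N(CC(=O)NC1COC1)c1nc(-c2ccccc2)cs1`) has (oxetan-3-yl)carbamoyl in place of phenyl on a saturated chain carbon bound to an amide-type nitrogen. Among the compounds with values here, no measured pair of compounds shows what such a swap does, so no change beyond the usual scatter is expected in this assay. The expected step is small, a number no higher from compound 3 to compound 4 (the limit leaves the size open). For compound 4 the estimate is 30000 nM, with an expected range of 12000 nM to 60000 nM.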

Compound 4, half-maximal inhibitory concentration: 20800 nM
Compound 4: the middle estimate sits 1.4-fold (0.16 log units) above what was measured; the range from low to high includes it.
By their numbers in this assay, from the lowest: compound 2; then compound 1; then compound 4. At a limit, above all of these: compound 3.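

In this assay, the saturated chain carbon bound to an amide-type nitrogen can carry (oxetan-3-yl)carbamoyl in place of phenyl and still give a measurable number. The swap brings an at least 1.4-fold lower number from compound 3 to compound 4 (0.15 log units; that floor lies within the scatter). How large the step truly is stays unknown because compound 3 stands at a limit, not a number: the limit of > 30000 nM in this assay, at which 1 of the 4 values shown sits.

From the compounds shown here alone, what an amine or a carboxylic acid on this carbon would give remains open. So does whether a longer chain would keep, lower or raise the number.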